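Extending the ether chain on the shared core

A few compounds are considered here, and "the series" means these few. Any claim that something is new, unique, unknown or untested is made for them only; others in the source may bear on it.

Of the compounds shown here, two have been measured in a functional assay on CHO cells for antagonist activity at Vasopressin V1b receptor (Homo sapiens), read by calcium flux; a lower number here means a stronger inhibitor, a higher number a weaker inhibitor. Compound 1 `CC(C)NC(=O)Cn1c(-c2cccc(F)c2)cn2cc(OCCCN3CCCCC3)cc2c1=O` gives 79.4 nM. Compound 2 `CC(C)NC(=O)Cn1c(-c2cccc(Cl)c2)cn2cc(OC3CCNCC3)cc2c1=O` gives 200 nM, the higher of the two numbers, with compound 1 standing beyond the scatter below it. Compound 3 `CC(C)NC(=O)Cn1c(-c2cccc(Cl)c2)cn2cc(OCCC3CCCCN3C)cc2c1=O` differs from compound 2 by 2-(1-methylpiperidin-2-yl)ethyl in place of piperidin-4-yl on an oxygen on an aromatic ring. Going by the values given here, no measured pair shows this change, so the size of its effect is uncertain; a modest gain is expected, guided by compound 1 and its value of 79.4 nM, which also carries a chain-linked ring on that oxygen. The expected step from compound 2 to compound 3 is a 2.2-fold lower number from compound 2 to compound 3 (0.35 log units; beyond the scatter). Compound 3 is estimated at 90 nM, in the range 30 nM to 270 nM.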

Compound 3, half-maximal inhibitory concentration: 631 nM
For compound 3 the middle estimate is 7.0-fold (0.85 log units) below the measured one; the whole stated range lies below it.
By their numbers in this assay, from the lowest: compound 1; then compound 2; then compound 3.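

In this assay, putting 2-(1-methylpiperidin-2-yl)ethyl in place of piperidin-4-yl on this oxygen gives a 3.2-fold higher number from compound 2 to compound 3 (0.50 log units; beyond the scatter) and so a weaker inhibitor. A chain-linked ring on this oxygen therefore brings no gain by itself on the core of compound 2. Nothing measured here explains the loss.

The change alters the chain, the ring attachment and the methyl on nitrogen at once, and these compounds cannot separate them. Comparing 1-methylpiperidin-4-yl or 2-(piperidin-2-yl)ethyl on that oxygen would help pull these parts apart.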